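The compounds below may be only part of what the source reports. "The series", "measured", "known", "first", "only" and "open" are said of these compounds alone.

Two measured compounds share one core and differ only in the group on the carbonyl carbon of the amide. Compound 1 is `O=C(Nc1ccc(Cl)c(-c2nnc3c(Cl)cccn23)c1)c1cccnc1`. In a functional assay on AN3-CA cells (Homo sapiens) for antiproliferative activity, read by MTT assay, with a stated time of 72 h (a lower number here means a stronger inhibitor, a higher number a weaker inhibitor), compound 1 gives > 100000 nM, which is a limit of the assay and not a number. Compound 2 is `O=C(Nc1ccc(Cl)c(-c2nnc3c(Cl)cccn23)c1)c1ccc(Cl)cc1`. In this assay compound 2 gives > 100000 nM, again a limit of the assay. Compound 2 therefore stands at the edge of what this assay can report, and the step that the two limits leave unreadable from compound 1 to compound 2 cannot be sized, because of the limit of > 100000 nM in this assay, at which 2 of the 2 values shown sit.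

Compound 3 is `O=C(Nc1ccc(Cl)c(-c2nnc3c(Cl)cccn23)c1)c1cccc(Cl)c1`. The change from compound 2 to compound 3 is 3-chlorophenyl in place of 4-chlorophenyl on a carbonyl carbon. The only measured step that bears on it, from compound 1 to compound 2, is unreadable, so no direction can be drawn from the numbers shown; both measured compounds sit at the limit. Compound 3 is expected to remain near that limit, with an expected step of a number no higher from compound 2 to compound 3 (the limit leaves the size open). The estimate for compound 3 in this assay is 100000 nM, in a range from 30000 nM to 300000 nM.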

Compound 3, half-maximal inhibitory concentration: 68400 nM
Beside the measured number, compound 3's estimate is 1.5-fold (0.16 log units) above it, and the stated range covers the measured number.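

In this assay, for the compounds shown here, compound 3 gives 68400 nM, the only number among the three compounds. Compound 1 and compound 2 each stand at a limit of the assay. With the same atoms joined differently, 3-chlorophenyl in place of 4-chlorophenyl on the carbonyl carbon gives an at least 1.4-fold lower number from compound 2 to compound 3 (0.16 log units; that floor lies within the scatter), and the same group in place of pyridin-3-yl gives an at least 1.4-fold lower number from compound 1 to compound 3 (0.16 log units; that floor lies within the scatter), so this position can yield a readable value, though both floors lie within the scatter and neither establishes a real change. The true size of either step stays open because only one side of each step is a number: the limit of > 100000 nM in this assay, at which 2 of the 3 values shown sit.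

The compounds shown leave open whether an amine, a methoxy group or a carboxylic acid in place of the chlorine of 3-chlorophenyl would move the number clearly beyond the scatter. They also leave open whether any group on this carbonyl carbon can bring the series far from the limit of this assay.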